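The source may hold more compounds than are shown below. What is called first, only, known or untested is meant among the compounds shown, and "the series" means these compounds.

Compound 3 `COC[C@H]1C[C@@](CC(C)C)(C(=O)O)N(C(=O)c2ccc(C(C)(C)C)c(OC)c2)[C@H]1COC(=O)OC` is one of three closely related acids carrying the same benzoyl group on the ring nitrogen. In an ADME assay on Huh-5-2 cells (Homo sapiens) for cytotoxicity, with a stated time of 3 days (on this read-out lower numbers stand for higher toxicity in this test and higher numbers for lower toxicity in this test), compound 3 gives > 120000 nM, which is a limit of the assay and not a number. Compound 1 `COC[C@H]1C[C@@](CC(C)C)(C(=O)O)N(C(=O)c2ccc(C(C)(C)C)c(OC)c2)[C@H]1[C@H]1COC(C)(C)O1` gives > 120000 nM in this assay, again a limit. Compound 2 `C=CCOC[C@H]1[C@@H](COC)C[C@@](CC(C)C)(C(=O)O)N1C(=O)c1ccc(C(C)(C)C)c(OC)c1` gives > 120000 nM in this assay, likewise a limit. All three values therefore rest at the limit of > 120000 nM in this assay, at which 3 of the 3 values shown sit, and the steps among them, a step that the two limits leave unreadable from compound 1 to compound 2, a step that the two limits leave unreadable from compound 1 to compound 3 and a step that the two limits leave unreadable from compound 2 to compound 3, cannot be read in size or direction.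

Compound 4 `COC[C@H]1C[C@@](CC(C)C)(C(=O)O)N(C(=O)c2ccc(C(C)(C)C)c(OC)c2)[C@H]1CN=[N+]=[N-]` differs from compound 3 in one place: azido in place of (methoxycarbonyl)oxy on a saturated chain carbon bound to a saturated ring carbon. For the measured compounds named here, none of the measured steps gives a readable size to build on, since each of them runs between two limits; what the three compounds do show is that the shared core has stayed without measurable toxicity whatever group sat on that saturated ring carbon, from a dioxolanyl to an allyloxymethyl to a carbonate-bearing methylene. On that basis the expected step from compound 3 to compound 4 is a step that the limit leaves unreadable from compound 3 to compound 4, that is, no movement beyond the scatter, with the most likely outcome that compound 4 also returns only a limit. The estimate for compound 4 in this assay is accordingly 150000 nM, with a range from 60000 nM to 400000 nM.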

Compound 4, half-maximal cytotoxic concentration: > 120000 nM
Compound 4 ended at the assay's limit; the forecaster's own chance of this, stated with the estimate: 80%; the middle value does not contradict the limit.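

In this assay compound 4 gives > 120000 nM, a limit of the assay and not a number. No step from compound 1, compound 2 or compound 3 to compound 4 can be read, since each runs between two limits: the limit of > 120000 nM in this assay, at which 4 of the 4 values shown sit.

The compounds shown leave open how much toxicity, if any, each of the four would show in this test, and whether any group at this place would give a measurable value.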